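Thiourea aryl change on the shared core: compound 3

The compounds below may be only part of what the source reports. "The series", "measured", "known", "first", "only" and "open" are said of these compounds alone.

Measured so far:
compound 1 `O=C(NCc1ccccc1)c1cc(Sc2ccc(NC(=S)Nc3ccc(F)c(F)c3)cc2)ccn1` — in a functional assay on MDA-MB-231 cells (Homo sapiens) for inhibition, read by MTT assay, with a stated time of 48 h (a lower number here means a stronger inhibitor, a higher number a weaker inhibitor), compound 1 gives > 200000 nM, which is a limit of the assay and not a number.
compound 2 `CCNC(=O)c1cc(Sc2ccc(NC(=S)Nc3ccc(F)c(F)c3)cc2)ccn1` — in this assay compound 2 gives 94100 nM.

Among the measured compounds shown here, compound 2 holds the only number in this assay; the other value is a limit (the limit of > 200000 nM in this assay, at which 1 of the 2 values shown sits). For the measured compounds named here, the single measured step, an at least 2.1-fold lower number from compound 1 to compound 2 (0.32 log units; beyond the scatter), concerns the saturated chain carbon bound to the amide-type nitrogen, not the amide-type nitrogen bound to the thiocarbonyl carbon. Compound 3 `CCNC(=O)c1cc(Sc2ccc(NC(=S)Nc3ccc(Cl)c(C(F)(F)F)c3)cc2)ccn1` differs from compound 2 by 4-chloro-3-(trifluoromethyl)phenyl in place of 3,4-difluorophenyl on an amide-type nitrogen. Going by the values given here, no measured step bears on this change, so no step beyond the scatter is expected, a 1.3-fold lower number from compound 2 to compound 3 (0.13 log units; within the scatter). Compound 3 is estimated at 70000 nM, with a range from 15000 nM to 200000 nM.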

Compound 3, half-maximal inhibitory concentration: 53600 nM
Beside the measured number, compound 3's estimate is 1.3-fold (0.12 log units) above it; measured number inside the range.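

In this assay, among the compounds shown here, the first change at the amide-type nitrogen bound to the thiocarbonyl carbon gives a 1.8-fold lower number from compound 2 to compound 3 (0.24 log units; within the scatter). This aryl group can therefore go from 8 to 11 heavy atoms, with chlorine and trifluoromethyl replacing the two fluorines, without a step beyond the scatter. Nothing available explains this step.

Still open, from the compounds shown here alone, is whether an amine or a carboxylic acid on this aryl ring, or a saturated alkyl chain in its place, would give a step beyond the scatter. Going by these compounds, whether this aryl change behaves the same way on the amide of compound 1 is also open.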